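Swapping the triazole for an oxazole on a quiet compound

The source may hold more compounds than are shown below. What is called first, only, known or untested is meant among the compounds shown, and "the series" means these compounds.

Swapping the triazole for an oxazole on a compound that already reads low.

Three amides sharing one core were measured in an ADME assay on PC-3 cells (Homo sapiens) for cytotoxicity, read by WST assay, tested at 100 uM; a lower number here means less inhibition, a higher number more inhibition at the concentration tested (going by the name of the read-out). Compound 1 `O=C(Nc1cccc(CN2CCCC2)c1)C1CCCN(C(=O)c2cc(C(F)(F)F)cc(C(F)(F)F)c2)C1` gives 51%, compound 2 `O=C(Nc1ccc(Cl)cc1)C1CCCN(C(=O)c2cc(C(F)(F)F)cc(C(F)(F)F)c2)C1` gives 14%, and compound 3 `Cn1cnnc1-c1cccc(NC(=O)C2CCCN(C(=O)c3cc(C(F)(F)F)cc(C(F)(F)F)c3)C2)c1` gives 0%, which leaves compound 3 as the lowest of the three numbers. The two steps that reach it are both drops: a number 51 percentage points lower from compound 1 to compound 3 (beyond the scatter) and a number 14 percentage points lower from compound 2 to compound 3 (beyond the scatter), while a number 37 percentage points lower from compound 1 to compound 2 (beyond the scatter) is the other large fall away from compound 1.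

Compound 4 `O=C(Nc1cccc(-c2cnco2)c1)C1CCCN(C(=O)c2cc(C(F)(F)F)cc(C(F)(F)F)c2)C1` differs from compound 3 by 1,3-oxazol-5-yl in place of 4-methyl-4H-1,2,4-triazol-3-yl on an aromatic carbon. Going by the values given here, no measured step exchanges one five-membered aromatic ring for another at this aromatic carbon; the closest is the step from compound 1 to compound 3, which introduced the 4-methyl-4H-1,2,4-triazol-3-yl and lowered the reading sharply, and the modest step from compound 2 to compound 3. Since compound 3 already sits at the floor, compound 4 is expected to move by a number 6 percentage points higher from compound 3 to compound 4 (within the scatter), which is within the scatter or only slightly above it. The estimate for compound 4 in this assay is 6%, between 0% and 22%.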

Compound 4, a percentage reported as inhibition, at one concentration (the size of the read-out at that concentration, not a potency): 9%
Estimate against measurement, compound 4: 3 percentage points below; the measured number falls inside the stated range.
By their numbers in this assay, from the lowest: compounds 3, 4 and 2 (each within the scatter of the next, the first and the last beyond it); then compound 1.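

In this assay, exchanging one five-membered aromatic ring for another at this aromatic carbon gives a number 9 percentage points higher from compound 3 to compound 4 (within the scatter) and so leaves compound 3 and compound 4 indistinguishable, which means the low reading is not confined to the 4-methyl-4H-1,2,4-triazol-3-yl. The 3-(1,3-oxazol-5-yl)phenyl group also stands level with 4-chlorophenyl, with a number 5 percentage points lower from compound 2 to compound 4 (within the scatter) on that exchange, while a number 42 percentage points lower from compound 1 to compound 4 (beyond the scatter) places the oxazole, like the triazole, well away from the (pyrrolidin-1-yl)methyl group. No measurement available here accounts for these readings.

The compounds shown leave open whether the high reading of compound 1 belongs to the pyrrolidine ring specifically or would persist with another amine on that methyl, such as dimethylamine or morpholine. They also leave open how a carboxylic acid at this aromatic carbon would read.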